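Fluoro in Place of Amino on Two Cores

This account rests on a few compounds, and the source may have more. Where it says the series, first, only, none or still open, it means among the compounds named here.

compound 1, `CC(=O)OC(C)n1cnc2c(Cl)nc(N)nc21`: > 500000 nM (a limit of the assay)
compound 2, `CC(=O)OC(C)n1cnc2c(Cl)nc(F)nc21`: 75900 nM
compound 3, `CC(=O)OCCOn1cnc2c(S)nc(N)nc21`: > 500000 nM (a limit of the assay)

In a functional assay on HT-29 cells (Homo sapiens) for inhibition (a higher number here means a weaker inhibitor, a lower number a stronger inhibitor), compound 1 gives > 500000 nM, which is a limit of the assay rather than a number. Compound 2 gives 75900 nM. The step of an at least 6.5-fold lower number from compound 1 to compound 2 (0.81 log units; beyond the scatter) goes with fluoro in place of amino on an aromatic carbon. Compound 3 gives > 500000 nM, again a limit. Two of the three values sit at the limit of > 500000 nM in this assay, at which 2 of the 3 values shown sit. The difference between the core of compound 3 and the core of compound 1 is not broken down here.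

Compound 4, `CC(=O)OCCOn1cnc2c(S)nc(F)nc21`, is not yet measured. It differs from compound 3 by fluoro in place of amino on an aromatic carbon. This is the same kind of change as from compound 1 to compound 2, though there the carbon is meta to a chloro group, whereas here it is meta to a sulfanyl group. The step expected for compound 4 is an at least 5.0-fold lower number from compound 3 to compound 4 (0.69 log units; beyond the scatter). That expectation rests on the step of an at least 6.5-fold lower number from compound 1 to compound 2 (0.81 log units; beyond the scatter), seen for the same change. Compound 4 is estimated at 100000 nM, between 20000 nM and 500000 nM.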

Compound 4, half-maximal inhibitory concentration: > 500000 nM
Compound 4 gave a limit, no number (the forecaster's own chance of this, stated with the estimate: 35%); middle value at least 5.0-fold (0.69 log units) away from the limit.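

In this assay, within the data shown here, compound 3 and compound 4 both give a limit of the assay rather than a number, so no step between them can be read: the limit of > 500000 nM in this assay, at which 3 of the 4 values shown sit. Going by these compounds, whether fluoro in place of amino on an aromatic carbon shifts the result on the core of compound 3, as it does on the core of compound 1, stays open.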